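Anilide substitution in the shared core: methyl for hydrogen

The source may hold more compounds than are shown below. What is called first, only, known or untested is meant among the compounds shown, and "the series" means these compounds.

Compound 1 `O=C(Nc1ccccc1)c1cc2cnc(Nc3ccc(N4CCNCC4)cn3)nc2n1C1CCCC1` is the reference of this set. In a functional assay on BXPC-3 cells (Homo sapiens) for inhibition, read by MTT assay (on this read-out lower numbers stand for stronger inhibition and higher numbers for weaker inhibition), compound 1 gives 5120 nM, which is the lowest of the two numbers available; its nearest neighbour is compound 2 `COc1cccc(NC(=O)c2cc3cnc(Nc4ccc(N5CCNCC5)cn4)nc3n2C2CCCC2)c1`, which in this assay gives 10500 nM. Among the measured compounds shown here, the one step within the shared core that is known so far, a 2.1-fold higher number from compound 1 to compound 2 (0.31 log units; beyond the scatter), is modest and is the only change on the anilide ring measured to date.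

Compound 3 `Cc1ccccc1NC(=O)c1cc2cnc(Nc3ccc(N4CCNCC4)cn3)nc2n1C1CCCC1` differs from compound 1 by methyl in place of hydrogen on an aromatic carbon. The same ring is touched as in the step from compound 1 to compound 2, and that step bears on the present one, though the entering group is smaller and sits at a different place. For the measured compounds named here, the single measured precedent shows a modest rise in the number when the anilide ring is substituted; an unrelated point is not available. A step of similar size or none beyond the scatter is therefore expected for compound 3, a 1.3-fold higher number from compound 1 to compound 3 (0.10 log units; within the scatter), with the direction, if any, towards a higher number. Compound 3 is estimated at 6500 nM in this assay, within the range 2500 nM to 17000 nM.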

Compound 3, half-maximal inhibitory concentration: 3340 nM
Compound 3: the middle estimate sits 1.9-fold (0.29 log units) above what was measured; measured number inside the range.
By their numbers in this assay, from the lowest: compounds 3 and 1 (each within the scatter of the next); then compound 2.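

In this assay, methyl in place of hydrogen on the aromatic carbon ortho to a large group gives a 1.5-fold lower number from compound 1 to compound 3 (0.19 log units; within the scatter), so this substitution of the anilide ring leaves the read-out within the scatter and a substituent here is tolerated. The phenyl ring therefore does not respond to substitution in one direction only: 2-methylphenyl gives a 3.1-fold lower number from compound 2 to compound 3 (0.50 log units; beyond the scatter) against 3-methoxyphenyl, and of the two substituted anilides only compound 2 stands beyond the scatter from compound 1. Nothing measured on these compounds accounts for the gap between compound 2 and compound 3.

Compound 2 and compound 3 differ in both the entering group and its place on the ring, so the compounds shown cannot separate the effect of methyl versus methoxy from that of the position. Also open, as far as these compounds go, is how a larger or different group on the same aromatic carbon, such as ethyl, chlorine, an amine or a carboxylic acid, would read, and whether a methoxy there would behave like the methyl of compound 3 or like the 3-methoxyphenyl of compound 2.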